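A few compounds are considered here, and "the series" means these few. Any claim that something is new, unique, unknown or untested is made for them only; others in the source may bear on it.

In a functional assay on HepG2 cells (Homo sapiens) for antiproliferative activity, read by MTT assay, with a stated time of 24 h (a lower number here means a stronger inhibitor, a higher number a weaker inhibitor), compound 3 `C=CCc1cc(-c2ccc(NC(C)=O)cc2)ccc1OC` reads 60100 nM and stands within the scatter of compound 1 `C=CCc1cc(-c2ccc(OC)cc2)cc(CC=C)c1O` at 69200 nM in the same read-out. Compound 2 `C=CCc1ccc(OCCC)c(-c2ccc(OCCC)c(CC=C)c2)c1` gives > 114000 nM here, which is a limit and not a number. Compound 4 `C=CCc1cc(-c2ccc(C(F)(F)F)cc2)ccc1OC` has trifluoromethyl in place of acetamido on an aromatic carbon, para to a large group, a change counted as trifluoromethyl in place of acetamido on an aromatic carbon from the structure of compound 3. Among the measured compounds shown here, no measured pair shows this change, so no step beyond the scatter is expected in this assay for it. The estimated 1.1-fold higher number from compound 3 to compound 4 (0.03 log units; within the scatter) is correspondingly small. Compound 4 is estimated at 65000 nM with 28000 nM as the expected lower end and 150000 nM as the upper end.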

Compound 4, half-maximal inhibitory concentration: 89000 nM
Estimate against measurement, compound 4: 1.4-fold (0.14 log units) below; measured number inside the range.
By their numbers in this assay, from the lowest: compounds 3, 1 and 4 (each within the scatter of the next). At a limit, above all of these: compound 2.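

In this assay, trifluoromethyl in place of acetamido gives a 1.5-fold higher number from compound 3 to compound 4 (0.17 log units; within the scatter), even though the hydrogen-bond donor and acceptor of acetamido leave with the change. Among the compounds shown here, this is the first single-place step, and it shows that this position, para to a large group, keeps its reading through the exchange of these two groups.

From the compounds shown here alone, whether an amine or a carboxylic acid at this position would read beyond the scatter from compound 3 stays open. Compound 2 remains a limit, not a number, and cannot anchor any step: the limit of > 114000 nM in this assay, at which 1 of the 4 values shown sits.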